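Triazole cytotoxicity series: methyl for phenyl in compound 2

A few compounds are considered here, and "the series" means these few. Any claim that something is new, unique, unknown or untested is made for them only; others in the source may bear on it.

Three compounds carry measured numbers in an ADME assay on HEp-2 cells (Homo sapiens) for cytotoxicity, read by MTT assay, with a stated time of 3 days; a higher number here means that more compound is tolerated, a lower number that less compound is tolerated. Compound 1 `CCCC[C@@H](CCn1cncn1)c1ccccc1` gives 40.8 ug/mL, compound 2 `c1ccc(C[C@@H](CCn2cncn2)c2ccccc2)cc1` gives 55.9 ug/mL, and compound 3 `c1ccc([C@H](CCn2cncn2)C2CCCCC2)cc1` gives 24.8 ug/mL. Compound 2 holds the highest of the three numbers; its nearest neighbour is compound 1, with a 1.4-fold higher number from compound 1 to compound 2 (0.14 log units; within the scatter), and its furthest is compound 3, with a 2.3-fold lower number from compound 2 to compound 3 (0.35 log units; beyond the scatter). The remaining measured step is a 1.6-fold lower number from compound 1 to compound 3 (0.22 log units; within the scatter).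

Compound 4 `C[C@H](CCn1cncn1)Cc1ccccc1` is not yet measured. It differs from compound 2 by methyl in place of phenyl on a saturated chain carbon bound to two saturated chain carbons.

Of the measured steps, the one that most resembles this change is the step from compound 1 to compound 2, where a phenyl entered in place of propyl on a saturated chain carbon and gave a 1.4-fold higher number from compound 1 to compound 2 (0.14 log units; within the scatter). Going by the values given here, the change to compound 4 runs the other way, a phenyl leaving for a methyl, and the only comparable swap sat within the scatter. The step from compound 2 to compound 3, a 2.3-fold lower number from compound 2 to compound 3 (0.35 log units; beyond the scatter), involves cyclohexyl and is less directly comparable. No step beyond the scatter is therefore expected; a slight drift toward compound 1 is as far as the evidence goes.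

The expected step is a 1.3-fold lower number from compound 2 to compound 4 (0.12 log units; within the scatter). Compound 4 is estimated at 42 ug/mL, with a range from 22 ug/mL to 80 ug/mL.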

Compound 4, half-maximal cytotoxic concentration: 144 ug/mL
Compound 4: middle estimate off by 3.4-fold (0.54 log units), on the low side, outside the stated range (above it).
By their numbers in this assay, from the lowest: compounds 3, 1 and 2 (each within the scatter of the next, the first and the last beyond it); then compound 4.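

In this assay, methyl in place of phenyl on a saturated chain carbon bound to two saturated chain carbons gives a 2.6-fold higher number from compound 2 to compound 4 (0.41 log units; beyond the scatter), so this position responds to this swap beyond the scatter, and in the direction of more compound tolerated. The earlier steps shown here only exchanged larger groups for one another at other places on the chain; this one shows that one six-membered aromatic ring of carbon only can leave the position, with methyl taking its place, without any loss in the number. No measurement shown accounts for the rise, so the step stands as an observation only.

Still open is whether the rise belongs to the arrival of methyl or to the departure of phenyl, since the compounds shown carry neither a bare hydrogen, an ethyl nor a longer chain at this carbon. On these data alone, it is equally open how an amine or a carboxylic acid at the same place would read, and whether methyl gives a step of the same direction on the cores of compound 1 and compound 3.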